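This account rests on a few compounds, and the source may have more. Where it says the series, first, only, none or still open, it means among the compounds named here.

Three compounds have been measured in a functional assay on A498 cells (Homo sapiens) for inhibition, read by sulforhodamine B assay, with a stated time of 48 h; on this read-out higher numbers stand for weaker inhibition and lower numbers for stronger inhibition:

Compound 1, `O=C(Nc1cccc(-n2cc(-c3ccncc3)c(-c3ccc(Cl)c(O)c3)n2)c1)Nc1cc(C(F)(F)F)cc(C(F)(F)F)c1`, gives 790 nM.
Compound 2, `COc1cc(-c2nn(-c3cccc(NC(=O)Nc4ccc(Cl)c(C(F)(F)F)c4)c3)cc2-c2ccncc2)ccc1Cl`, gives 840 nM.
Compound 3, `COc1cc(-c2nn(-c3cccc(NC(=O)c4ccccc4)c3)cc2-c2ccncc2)ccc1Cl`, gives 360 nM.

Among these three numbers compound 1 stands second highest. Compound 2 sits closest to it, the two numbers lying within the usual scatter of each other, so nothing can be said about which inhibits more strongly. Compound 3 lies furthest from compound 1, with a number lower by an amount beyond the scatter.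

Compound 4, `O=C(Nc1cccc(-n2cc(-c3ccncc3)c(-c3ccc(Cl)c(O)c3)n2)c1)Nc1cccc(C(F)(F)F)c1`, has not yet been measured in this assay. It differs from compound 1 in one place: hydrogen in place of trifluoromethyl on an aromatic carbon. Among the measured compounds shown here, the only measured step that involves a single change is a 2.3-fold lower number from compound 2 to compound 3 (0.37 log units; beyond the scatter); that step alters the group on the carbonyl carbon, not a trifluoromethyl on the ring, so it does not bear directly on the change from compound 1 to compound 4. For the measured compounds named here, no measured pair shows what losing one trifluoromethyl does.

With no direct guide, the expected step is small: a 1.4-fold higher number from compound 1 to compound 4 (0.14 log units; within the scatter) is estimated, leaning toward a slightly higher number, but within or close to the scatter. Compound 4 is therefore expected to give about 1100 nM, in a range from 450 nM to 2800 nM.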

Compound 4, half-maximal inhibitory concentration: 2240 nM
For compound 4 the middle estimate is 2.0-fold (0.31 log units) below the measured one; measured number inside the range.
By their numbers in this assay, from the lowest: compound 3; then compounds 1 and 2 (each within the scatter of the next); then compound 4.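

Among the compounds shown here, until now, no pair of compounds isolated the effect of a trifluoromethyl group on this ring. In this assay, replacing one trifluoromethyl with hydrogen gives a 2.8-fold higher number from compound 1 to compound 4 (0.45 log units; beyond the scatter), so inhibition is weaker, by a modest step that lies beyond the scatter. This shows that the trifluoromethyl at this aromatic carbon, meta to a large group and meta to a trifluoromethyl group, cannot be removed without a measurable loss in this assay, although a single pair says nothing about other positions or other cores. No measurement at hand offers a reason for this loss.

As far as these compounds go, it remains open whether trifluoromethyl itself is needed at this carbon, or whether another group, such as a nitrile, a tert-butyl group or a carboxylic acid, would give a number closer to that of compound 1. For the compounds shown here, it also remains open whether the same replacement would have a similar effect in a compound carrying methoxy rather than hydroxy on the chloro-substituted ring, since no pair here tests that.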